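A Ring Amine in Place of a Phenyl Amine

The compounds below may be only part of what the source reports. "The series", "measured", "known", "first", "only" and "open" are said of these compounds alone.

Compound 1 `CCOC(=O)c1cc(=O)c2cc(CSC(=S)N(C)c3ccccc3)ccc2o1` is tested in a functional assay on SW480 cells (Homo sapiens) for antiproliferative activity, read by MTT assay, with a stated time of 72 h; on this read-out higher numbers stand for weaker inhibition and lower numbers for stronger inhibition. For compound 1 this assay returns only a limit, > 25000 nM, so its true value is not pinned down; it sits at the limit of > 25000 nM in this assay, at which 1 of the 3 values shown sits. Two related compounds give context. Compound 2 `Cc1ccc2c(=O)c(CSC(=S)N3CCOCC3)coc2c1` carries a different ring amine on the same thiocarbonyl carbon and gives a measured value of 3800 nM in this assay. Compound 3 `CC(C)N(C(=S)SCc1cc(=O)c2ccccc2o1)C(C)C` carries two isopropyl groups there, and in this assay it also stops at a limit, > 40000 nM, which is the limit of > 40000 nM in this assay, at which 1 of the 3 values shown sits. Within the data shown here, no pair of measured compounds here differs in a single place, so nothing measured fixes how far a change at this position moves the read-out.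

Compound 4 `CCOC(=O)c1cc(=O)c2cc(CSC(=S)N3CCCCC3)ccc2o1` is not yet measured. It differs from compound 1 in one place: piperidin-1-yl in place of methyl(phenyl)amino on a thiocarbonyl carbon. Compound 4 is expected to move toward stronger inhibition in this assay, by a step of an at least 2.0-fold lower number from compound 1 to compound 4 (0.31 log units; beyond the scatter), since compound 2 gives 3800 nM with a non-aromatic ring amine on the thiocarbonyl carbon. Because compound 1 gives only > 25000 nM, the size of that step is uncertain. For compound 4 the expected value is 12000 nM, with a likely range from 3000 nM to 50000 nM.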

Compound 4, half-maximal inhibitory concentration: > 25000 nM
Compound 4: a limit, no number (the forecaster's own chance of this, stated with the estimate: 40%); middle value at least 2.0-fold (0.31 log units) away from the limit.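

In this assay compound 4 gives only a limit, > 25000 nM. Compound 1 also gives only a limit, so no step can be read between compound 1 and compound 4, and both sit at the same one: the limit of > 25000 nM in this assay, at which 2 of the 4 values shown sit. As far as these compounds go, whether piperidin-1-yl or methyl(phenyl)amino on the thiocarbonyl carbon gives stronger inhibition stays open.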